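A Larger Group on the Oxygen-Bearing Carbon

The compounds below may be only part of what the source reports. "The series", "measured", "known", "first", "only" and "open" are said of these compounds alone.

Of the compounds shown here, three sharing a dioxide core have been measured in a functional assay on A549 cells (Homo sapiens) for cytotoxicity, read by MTT assay, with a stated time of 72 h; a higher number here means a weaker inhibitor, a lower number a stronger inhibitor. Compound 1 `COc1ccc2c(c1)[n+]([O-])nc(NCOC(C)c1ccccc1)[n+]2[O-]` gives 220 nM. Compound 2 `[O-][n+]1nc(NCOC2CCCCC2)[n+]([O-])c2ccccc21` gives 1200 nM. Compound 3 `COCNc1n[n+]([O-])c2ccccc2[n+]1[O-]` gives 2770 nM, which is the highest of the three numbers; its nearest neighbour is compound 2, and compound 1 lies furthest from it.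

Compound 4 `[O-][n+]1nc(NCOCc2ccc(Cl)cc2)[n+]([O-])c2ccccc21` has not yet been measured in this assay. It differs from compound 3 in one place: 4-chlorophenyl in place of hydrogen on a saturated chain carbon bound to an oxygen on a saturated carbon.

Among the compounds with values here, one measured step bears on this change. Going from compound 2 to compound 3 put methyl in place of cyclohexyl on an oxygen on a saturated carbon and produced a 2.3-fold higher number from compound 2 to compound 3 (0.36 log units; beyond the scatter), so removing a larger group from that position raised the number. Compound 4 goes the other way, placing 4-chlorophenyl on the saturated chain carbon bound to that oxygen, and a lower number is therefore expected. Within the data shown here, compound 1, which carries a phenyl-bearing group at a similar position together with a methoxy on the core, gives the lowest number of the three, but no single-place step connects it to compound 3.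

Compound 4 is thus estimated to give 1000 nM in this assay, within a range of 400 nM to 2500 nM, which corresponds to an expected step of a 2.8-fold lower number from compound 3 to compound 4 (0.44 log units; beyond the scatter).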

Compound 4, half-maximal inhibitory concentration: 2190 nM
Beside the measured number, compound 4's estimate is 2.2-fold (0.34 log units) below it; the range from low to high includes it.
By their numbers in this assay, from the lowest: compound 1; then compounds 2, 4 and 3 (each within the scatter of the next, the first and the last beyond it).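

In this assay, setting 4-chlorophenyl in place of hydrogen on a saturated chain carbon bound to an oxygen on a saturated carbon gave a 1.3-fold lower number from compound 3 to compound 4 (0.10 log units; within the scatter). The earlier step, with methyl in place of cyclohexyl, gave a 2.3-fold higher number from compound 2 to compound 3 (0.36 log units; beyond the scatter), and on its own it could be read as a sign that a larger group at this part of the side chain goes with a lower number, but compound 4 goes against that reading, since a group as large as 4-chlorophenyl left its number within the scatter of the number for compound 3. Nothing available explains this result.

The compounds shown leave open whether the chlorine of compound 4 matters, which a plain phenyl, a 4-methoxyphenyl or a 4-fluorophenyl on the same carbon would test, and how an amine, a carboxylic acid or a longer chain would behave there. They also leave open what lies behind the 220 nM of compound 1, which differs from the others in more than one place, so that neither its methoxy on the core nor its phenyl-bearing side chain can be credited with that number on its own.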